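From Chloro to Fluoro in a Small Series

A few compounds are considered here, and "the series" means these few. Any claim that something is new, unique, unknown or untested is made for them only; others in the source may bear on it.

For the measured compounds named here, in a functional assay on NCI-H661 cells (Homo sapiens) for inhibition, read by MTT assay, with a stated time of 72 h (on this read-out higher numbers stand for weaker inhibition and lower numbers for stronger inhibition), compound 2 `Nc1ccccc1NC(=O)c1ccc(CNCc2nc(-c3ccc(Cl)cc3)no2)cc1` gives 8000 nM, the lowest of the two numbers so far, while compound 1 `Nc1ccccc1NC(=O)c1ccc(CNCc2nc(-c3ccc(C(F)(F)F)cc3)no2)cc1` gives 23500 nM. Compound 3 `Nc1ccccc1NC(=O)c1ccc(CNCc2nc(-c3ccc(F)cc3)no2)cc1` has fluoro in place of chloro on an aromatic carbon, para to a large group: fluoro in place of chloro on an aromatic carbon. Going by the values given here, only one measured step changes this same place: a 2.9-fold lower number from compound 1 to compound 2 (0.47 log units; beyond the scatter), a modest move with chloro in place of trifluoromethyl. It does not show what fluoro will do, so no step beyond the scatter is expected in this assay. The expected step is a 1.1-fold higher number from compound 2 to compound 3 (0.05 log units; within the scatter). The estimate for compound 3 is 9000 nM, with a range from 3500 nM to 25000 nM.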

Compound 3, half-maximal inhibitory concentration: 4360 nM
For compound 3 the middle estimate is 2.1-fold (0.31 log units) above the measured one; the measured number falls inside the stated range.
By their numbers in this assay, from the lowest: compounds 3 and 2 (each within the scatter of the next); then compound 1.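

Fluoro in place of chloro gives a 1.8-fold lower number from compound 2 to compound 3 (0.26 log units; within the scatter) in this assay, so on this aromatic carbon these two halogens cannot be told apart. Fluoro in place of trifluoromethyl gives a 5.4-fold lower number from compound 1 to compound 3 (0.73 log units; beyond the scatter) and this second clear step sets compound 1 apart from both halogen compounds. Among these three groups, only trifluoromethyl stands out at this position. Going by these compounds, whether an amine, a methoxy group or plain hydrogen at this same place would match the halogens remains open. Nothing available gives a reason for these differences.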